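Urea series: solubility notes toward compound 3

The source may hold more compounds than are shown below. What is called first, only, known or untested is meant among the compounds shown, and "the series" means these compounds.

Two measured ureas share a core. Compound 1 `Cc1ccc(NC(=O)Nc2cc(C)nc3ccccc23)cc1` carries a methyl group on the terminal aromatic ring; in a physicochemical assay for solubility, at pH 7.4 (on this read-out higher numbers stand for higher solubility and lower numbers for lower solubility), compound 1 gives 1300 nM. Compound 2 `CSc1ccccc1NC(=O)Nc1cc(C)nc2ccccc12` carries a methylsulfanyl group instead; in this assay compound 2 gives 21000 nM. Compound 2 thus stands highest of the two numbers, and the nearest value, that of compound 1, lies well beyond the usual scatter of this read-out. Among the measured compounds shown here, the two compounds differ in more than one place, so no single step is drawn between them.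

Compound 3 `COc1ccccc1NC(=O)Nc1cc(C)nc2ccccc12` follows from compound 2 by one change: methoxy in place of methylsulfanyl on an aromatic carbon. For the measured compounds named here, no measured pair shows this exchange here. For compound 3 a small step in this assay, upward or within the scatter, is expected, as estimated by a 1.4-fold higher number from compound 2 to compound 3 (0.15 log units; within the scatter). On that basis compound 3 is expected to give about 30000 nM in this assay, within a range of 12000 nM to 75000 nM.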

Compound 3, solubility: 100 nM
Beside the measured number, compound 3's estimate is 300-fold (2.48 log units) above it, and the stated range ends above it.
By their numbers in this assay, from the lowest: compound 3; then compound 1; then compound 2.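

In this assay, methoxy in place of methylsulfanyl on an aromatic carbon, ortho to a large group, gives a 210-fold lower number from compound 2 to compound 3 (2.32 log units; beyond the scatter), so this position is far from indifferent to the exchange. The two groups match in heavy-atom count and in hydrogen-bond donors and acceptors and differ in oxygen against sulfur, which shows that a swap leaving those counts unchanged can still produce a large step in this series. No supporting evidence bears on this result.

Going by these compounds, whether a step of this size holds for the same exchange elsewhere on the ring, or on a different core, remains open. Also open, on these data alone, is how an amine, a carboxylic acid or a longer chain such as ethoxy would read at this position in this assay.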